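The source may report more compounds than this note shows. Statements on the series, on what has been measured and on what is new or still open speak of the compounds shown alone.

Measured so far:
- compound 1, `O=S(=O)(O)c1ccc(/N=N/c2c(O)ccc3ccccc23)c2ccccc12`: in an assay on BaF3 cells with thrombopoietin receptor (Homo sapiens) as the target, read by a luciferase reporter (a lower number here means a smaller maximal response, a higher number a larger maximal response), compound 1 gives a limit of the assay, < 5%.
- compound 2, `O=S(=O)(O)c1cc(O)c(/N=C/c2c(O)ccc3ccccc23)c2ccccc12`: in this assay compound 2 also gives a limit of the assay, < 5%.
- compound 3, `Cc1[nH]n(-c2cccc(C(F)(F)F)c2)c(=O)c1/N=N/c1c(O)cc(S(=O)(=O)O)c2ccccc12`: in this assay compound 3 gives 62%.

Compound 3 is the only one of the three with a number rather than a limit in this assay; the other two sit at the limit of < 5% in this assay, at which 2 of the 3 values shown sit. Among the measured compounds shown here, no pair of measured compounds differs in a single place, so nothing here tells how large a one-point change moves the response in this assay.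

Compound 4, `Cc1[nH]n(-c2ccc(S(=O)(=O)O)cc2)c(=O)c1/N=N/c1c(O)cc(S(=O)(=O)O)c2ccccc12`, has not yet been measured. It keeps the core of compound 3 and differs from it in one place: 4-sulfophenyl in place of 3-(trifluoromethyl)phenyl on an aromatic nitrogen.

For the measured compounds named here, with no comparable step in hand, the expectation is a moderate loss of response in this assay on going to compound 4, the step being estimated as a number 22 percentage points lower from compound 3 to compound 4 (beyond the scatter). Compound 4 is expected to give 40%, most likely within 5% to 75%, with a fair chance that only a limit is reported.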

Compound 4, largest response reached (reported as efficacy), in percent of the reference or control that the assay uses: < 5%
Compound 4: no number, only a limit; the forecaster's own chance of this, stated with the estimate: 25%; at least 35 percentage points between middle value and limit.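

With the rest of compound 3 kept, the group on the aromatic nitrogen proves decisive for the maximal response in this assay: 4-sulfophenyl in place of 3-(trifluoromethyl)phenyl gives a number at least 57 percentage points lower from compound 3 to compound 4 (beyond the scatter). Compound 4 gives < 5%, which is a limit of the assay and not a number. The step therefore has a minimum size only, and compound 4 joins the compounds at the floor of the read-out: the limit of < 5% in this assay, at which 3 of the 4 values shown sit.

This single change alters both the substituent and its place on the phenyl ring, so the two contributions cannot be separated. Going by these compounds, the response in this assay remains open for an unsubstituted phenyl and for a phenyl carrying a carboxylic acid or an amine on this nitrogen.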